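From aryl to cyclopropylmethyl at the assay limit

This account rests on a few compounds, and the source may have more. Where it says the series, first, only, none or still open, it means among the compounds named here.

In a physicochemical assay for solubility, using the shake flask method, in phosphate buffer, measured as kinetic solubility, with a stated time of 20 h, at pH 6.5 (a lower number here means a less soluble compound, a higher number a more soluble compound), compound 2 `FC(F)(F)c1ccc(Nc2cc3[nH]c(-c4cccc(C(F)(F)F)c4)nc3cn2)nc1` gives < 5000 nM, a limit and not a number. Compound 1 `N#Cc1ccc(Nc2cc3[nH]c(-c4cccc(C(F)(F)F)c4)nc3cn2)nc1` gives < 5000 nM, also a limit. Compound 3 `O=C(O)c1ccnc(Nc2cc3[nH]c(-c4cccc(C(F)(F)F)c4)nc3cn2)c1` gives < 5000 nM, again a limit. The evidence so far is the limit of < 5000 nM in this assay, at which 3 of the 3 values shown sit.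

The measured steps are a step that the two limits leave unreadable from compound 1 to compound 2, a step that the two limits leave unreadable from compound 1 to compound 3 and a step that the two limits leave unreadable from compound 2 to compound 3. None has a readable size, and none touches the group that changes next.

Compound 4 `FC(F)(F)c1ccc(Nc2cc3[nH]c(CC4CC4)nc3cn2)nc1` carries cyclopropylmethyl in place of 3-(trifluoromethyl)phenyl on an aromatic carbon. The expectation therefore rests on this structural change alone, and it is only tentative. An upward move is expected, with the estimated step being an at least 3.0-fold higher number from compound 2 to compound 4 (0.47 log units; beyond the scatter). For compound 4 the expected value is 15000 nM, with an estimated range of 4000 nM to 80000 nM.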

Compound 4, solubility: 118000 nM
The estimate for compound 4 lay 7.9-fold (0.90 log units) below the measured number, outside the stated range (above it).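

In this assay, for the compounds shown here, cyclopropylmethyl in place of 3-(trifluoromethyl)phenyl on this aromatic carbon gives an at least 23-fold higher number from compound 2 to compound 4 (1.37 log units; beyond the scatter), the first step here with a readable size, and it is large. The earlier steps cannot be read, so this position is the only one shown where a change leaves the limit: the limit of < 5000 nM in this assay, at which 3 of the 4 values shown sit.

From the compounds shown here alone, compound 2 gives only a limit, so the full size of the step stays open. Also open, going by these compounds, is whether an amine or a longer chain at this carbon would give a similar number, and whether the same change holds with other groups on the nitrogen.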